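From iodo to methoxy on the shared core

The compounds below may be only part of what the source reports. "The series", "measured", "known", "first", "only" and "open" are said of these compounds alone.

Values in an ADME assay on L929 cells (Mus musculus) for cytotoxicity, read by resazurin assay, with a stated time of 72 h; on this read-out lower numbers stand for stronger inhibition and higher numbers for weaker inhibition:
- Compound 1 `CCc1ccc(C(=O)/C=C/c2ccc3c(c2)B(O)OC3)cc1`: > 10 ug/mL (a limit)
- Compound 2 `COc1ccc(C(=O)/C=C/c2ccc3c(c2)B(O)OC3)c(OC)c1`: 7.87 ug/mL
- Compound 3 `O=C(/C=C/c1ccc2c(c1)B(O)OC2)c1ccc(I)cc1`: > 10 ug/mL (a limit)

Compound 3 has only a limit, > 10 ug/mL, and no exact number. That same limit is shared across the set, as the limit of > 10 ug/mL in this assay, at which 2 of the 3 values shown sit, shows. Among the compounds with values here, the one measured step, a step that the two limits leave unreadable from compound 1 to compound 3, therefore gives no size to build on.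

Compound 4 `COc1ccc(C(=O)/C=C/c2ccc3c(c2)B(O)OC3)cc1` puts methoxy in place of iodo on an aromatic carbon, para to a large group: methoxy in place of iodo on an aromatic carbon.

Compound 2, which also carries methoxy, gives 7.87 ug/mL, so a modest shift towards stronger inhibition is expected in this assay. The expected change is an at least 1.1-fold lower number from compound 3 to compound 4 (0.04 log units; that floor lies within the scatter). Compound 4 is estimated at 9 ug/mL, with an expected range from 4 ug/mL to 20 ug/mL.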

Compound 4, half-maximal inhibitory concentration: > 10 ug/mL
Compound 4: only a limit was reported (the forecaster's own chance of this, stated with the estimate: 50%); middle value at least 1.1-fold (0.04 log units) away from the limit.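

Compound 4 gives > 10 ug/mL in this assay and that is a limit, not a number. Methoxy para to a large group therefore joins ethyl and iodo at this limit, and the steps among compound 1, compound 3 and compound 4 cannot be read. Hydrogen in place of the second methoxy of compound 2 gives an at least 1.2-fold higher number from compound 2 to compound 4 (0.10 log units; that floor lies within the scatter) and so shows no sure change.

Still open, from the compounds shown here alone, is how far beyond the limit these three compounds lie, and whether an amine or a carboxylic acid at this position would give a measurable number.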